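This account rests on a few compounds, and the source may have more. Where it says the series, first, only, none or still open, it means among the compounds named here.

Compound 1 `COc1cc(O)c(CC=C(C)C)c(O)c1C(=O)/C=C/c1ccc([N+](=O)[O-])cc1` and compound 2 `COc1cc(O)c(CC=C(C)C)c(O)c1C(=O)/C=C/c1cccc([N+](=O)[O-])c1` share a core and differ only as 3-nitrophenyl in place of 4-nitrophenyl on a double-bonded chain carbon bound to a double-bonded chain carbon. In a functional assay on HepG2 cells (Homo sapiens) for inhibition, read by MTT assay, with a stated time of 72 h (on this read-out lower numbers stand for stronger inhibition and higher numbers for weaker inhibition), compound 1 gives 12400 nM, and compound 2 gives 16600 nM, so that a 1.3-fold higher number from compound 1 to compound 2 (0.13 log units; within the scatter). Compound 3 `COc1cc(O)cc(O)c1C(=O)/C=C/c1ccc([N+](=O)[O-])cc1` arises from compound 1 by hydrogen in place of 3-methylbut-2-en-1-yl on an aromatic carbon; in this assay compound 3 gives 41000 nM, and a 3.3-fold higher number from compound 1 to compound 3 (0.52 log units; beyond the scatter). Compound 4 `COc1cc(O)cc(O)c1C(=O)/C=C/c1cccc([N+](=O)[O-])c1` arises from compound 2 by the same change, (hydrogen in place of 3-methylbut-2-en-1-yl on an aromatic carbon), and has not yet been measured in this assay. Since the step from compound 1 to compound 3 was modest but beyond the scatter, a step of like size is expected from compound 2 to compound 4, that is a 3.3-fold higher number from compound 2 to compound 4 (0.52 log units; beyond the scatter), resting on a 3.3-fold higher number from compound 1 to compound 3 (0.52 log units; beyond the scatter). Compound 4 is therefore estimated at 55000 nM, plausibly between 25000 nM and 120000 nM.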

Compound 4, half-maximal inhibitory concentration: 16300 nM
Estimate against measurement, compound 4: 3.4-fold (0.53 log units) above; the whole stated range lies above it.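

In this assay, hydrogen in place of 3-methylbut-2-en-1-yl now gives a 1.0-fold lower number from compound 2 to compound 4 (0.01 log units; within the scatter). The same change therefore does not carry over at a like size from one core to the other: the same change on two cores in this assay, a 3.3-fold higher number (0.52 log units; beyond the scatter) from compound 1 to compound 3 and a 1.0-fold lower number (0.01 log units; within the scatter) from compound 2 to compound 4, 3.4-fold (0.53 log units) apart, beyond the scatter of two such steps. This shows that, in this series, the step read on the 4-nitrophenyl core cannot simply be transferred to the 3-nitrophenyl core, but these two pairs do not show why the steps differ or what size the step would take on any further core.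

The compounds shown leave open how the change would behave with an amine in place of the nitro group. They also leave open what a longer chain than 3-methylbut-2-en-1-yl would give on that aromatic carbon.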